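Swapping a Cyclobutyl for a tert-Butylamino Group

The compounds below may be only part of what the source reports. "The series", "measured", "known", "first", "only" and "open" are said of these compounds alone.

Of the compounds shown here, three have so far been tested in a functional assay on MIA PaCa-2 cells (Homo sapiens) for inhibition, read by MTT assay, with a stated time of 3 days; a lower number here means a stronger inhibitor, a higher number a weaker inhibitor. Compound 1 `CC(C)c1noc(N2CCN(C(=O)[C@@H]3CCCN(S(=O)(=O)c4ccc(S(=O)(=O)C(C)C)cc4)C3)CC2)n1` gives > 10000 nM in this assay, which is a limit of the assay rather than a number. Compound 2 `CC(C)c1noc(N2CCN(C(=O)[C@@H]3CCCN(S(=O)(=O)c4ccc(S(=O)(=O)C5CCC5)cc4)C3)CC2)n1` gives > 10000 nM in this assay, again a limit. Compound 3 `CCOC(=O)N1CCC[C@@H](S(=O)(=O)c2ccc(S(=O)(=O)N(CC)CC)cc2)C1` gives > 10000 nM in this assay, also a limit. Within the data shown here, the only step between compounds that differ in one place is a step that the two limits leave unreadable from compound 1 to compound 2, which the two limits leave unreadable. All three values share (the limit of > 10000 nM in this assay, at which 3 of the 3 values shown sit), so compound 2 stands exactly where every measured compound stands, with no number of its own to mark it out.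

Compound 4 `CC(C)c1noc(N2CCN(C(=O)[C@@H]3CCCN(S(=O)(=O)c4ccc(S(=O)(=O)NC(C)(C)C)cc4)C3)CC2)n1` differs from compound 2 by (tert-butyl)amino in place of cyclobutyl on a sulfonyl sulfur. Among the measured compounds shown here, no measured step bears directly on this change, and the single step that has been measured cannot be read. There is therefore no ground to expect compound 4 to move beyond the scatter in either direction, and the most likely outcome is another limit. Compound 4 is expected to give about 15000 nM in this assay, within a range from 5000 nM to 50000 nM. The estimated step is a step that the limit leaves unreadable from compound 2 to compound 4.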

Compound 4, half-maximal inhibitory concentration: > 10000 nM
Compound 4: only a limit was reported; the forecaster's own chance of this, stated with the estimate: 85%; the middle value lies beyond the limit too.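

In this assay compound 4 gives > 10000 nM, which is a limit and not a number, so the steps to compound 4 from compound 1 and from compound 2 cannot be read. The compounds shown leave open whether any group on the sulfonyl sulfur would give a readable number, because all of them share one result: the limit of > 10000 nM in this assay, at which 4 of the 4 values shown sit.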